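Moving the Indazole Attachment: Compound 2 to Compound 3

The source may hold more compounds than are shown below. What is called first, only, known or untested is meant among the compounds shown, and "the series" means these compounds.

Measured in a physicochemical assay for solubility; a lower number here means a less soluble compound, a higher number a more soluble compound:
Compound 1 `CNC(=O)c1cc(C(=O)NC2CC2)cn(Cc2cccc3[nH]ccc23)c1=O`: 78 ug/mL
Compound 2 `CNC(=O)c1cc(C(=O)NC2CC2)cn(Cc2cccc3cn[nH]c23)c1=O`: >= 181 ug/mL

Compound 2 stands at the limit of >= 181 ug/mL in this assay, at which 1 of the 2 values shown sits, so its reading is a limit and not a number. The measured step is an at least 2.3-fold higher number from compound 1 to compound 2 (0.36 log units; beyond the scatter), which lies beyond the scatter. That step put 1H-indazol-7-yl in place of 1H-indol-4-yl.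

Compound 3 `CNC(=O)c1cc(C(=O)NC2CC2)cn(Cc2cccc3[nH]ncc23)c1=O` has not yet been measured. It has the same atoms as compound 2, joined differently: 1H-indazol-4-yl in place of 1H-indazol-7-yl on a saturated chain carbon bound to an aromatic nitrogen. Among the measured compounds shown here, its group shares the indazolyl name with compound 2 and the 4-yl attachment with compound 1, so the one measured step bears on it only indirectly. That step changed the group and its attachment together, and it does not show what moving the attachment alone would do.

For the measured compounds named here, with an at least 2.3-fold higher number from compound 1 to compound 2 (0.36 log units; beyond the scatter) as the only guide, a small downward change is expected in this assay, possibly none beyond the scatter. The expected step is an at least 1.2-fold lower number from compound 2 to compound 3 (0.08 log units; that floor lies within the scatter). Compound 3 is estimated at 150 ug/mL, with an expected range of 70 ug/mL to 280 ug/mL.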

Compound 3, solubility: 10 ug/mL
The estimate for compound 3 lay 15-fold (1.18 log units) above the measured number; measured number outside the range, below it.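

In this assay, moving the attachment alone, with 1H-indazol-4-yl in place of 1H-indazol-7-yl on a saturated chain carbon bound to an aromatic nitrogen, gave an at least 18-fold lower number from compound 2 to compound 3 (1.25 log units; beyond the scatter), so at this place the way the group is joined matters a great deal even though the atoms and the counts on both sides are the same. The reading of compound 2 is a limit and not a number, so the true size of that step stays open on one side: the limit of >= 181 ug/mL in this assay, at which 1 of the 3 values shown sits.

With the 4-yl attachment held, 1H-indazol-4-yl in place of 1H-indol-4-yl gave a 7.8-fold lower number from compound 1 to compound 3 (0.89 log units; beyond the scatter), so the indazolyl name alone does not go with the higher number, since compound 2 and compound 3 both carry it and fall on opposite sides of compound 1.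

The compounds shown leave open how 1H-indazol-5-yl or 1H-indazol-6-yl would read at this place, and whether 1H-indol-7-yl would follow the same order of attachments as the indazolyl pair. They also leave open how far compound 2 truly stands beyond its limit, and what lies behind the difference between the two attachments.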